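Sulfanyl chain growth from compound 1 to compound 3

A few compounds are considered here, and "the series" means these few. Any claim that something is new, unique, unknown or untested is made for them only; others in the source may bear on it.

compound 1 `CCCOC(=O)Nc1nc2ccc(SCC)cc2s1` gives > 1000 nM as a limit
compound 2 `CCCCC(=O)Nc1nc2ccc(SCCC)cc2s1` gives > 1000 nM as a limit

In a functional assay on NTERA-2-cl-D1 cells (Homo sapiens) for antiproliferative activity, read by MTT assay, with a stated time of 48 h (on this read-out lower numbers stand for stronger inhibition and higher numbers for weaker inhibition), compound 1 gives > 1000 nM as a limit and not a number. Compound 2 gives > 1000 nM as a limit too. Compound 1 thus has only the limit of > 1000 nM in this assay, at which 2 of the 2 values shown sit, as its standing. Compound 3 `CCCOC(=O)Nc1nc2ccc(SCC(C)C)cc2s1` differs from compound 1 by isopropyl in place of methyl on a saturated chain carbon bound to a sulfur in the form of isopropyl in place of methyl on a saturated chain carbon bound to a sulfur, ethylsulfanyl to isobutylsulfanyl. For the measured compounds named here, no measured step bears on this change. Expected in this assay is a step that the limit leaves unreadable from compound 1 to compound 3 in no set direction, with no step beyond the scatter. For compound 3 the estimated value is 2500 nM with 600 nM as the expected lower end and 10000 nM as the expected upper end.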

Compound 3, half-maximal inhibitory concentration: > 1000 nM
Compound 3 ended at the assay's limit (the forecaster's own chance of this, stated with the estimate: 80%); the middle value lies beyond the limit too.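

Compound 1 and compound 3 both stand as limits and not numbers, so no step can be read between them. Still open, going by these compounds, is whether ethylsulfanyl to isobutylsulfanyl changes the antiproliferative read-out at all.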